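Removing one methoxy from compound 2

The source may report more compounds than this note shows. Statements on the series, on what has been measured and on what is new or still open speak of the compounds shown alone.

Of the compounds shown here, two with a shared core have been read so far, and a third awaits measurement. In a functional assay on PC-3 cells (Homo sapiens) for cytotoxicity, read by WST assay, with a stated time of 24 h (a higher number here means a weaker inhibitor, a lower number a stronger inhibitor), compound 1 (`COc1ccc2c(/C=C(\C#N)C(=O)c3c[nH]c4cc(OC)ccc34)c[nH]c2c1`) gives > 50000 nM, which is a limit of the assay and not a number. Within the data shown here, compound 2 (`COc1ccc2c(C(=O)/C(C#N)=C/c3c[nH]c4ccc(OC)cc34)c[nH]c2c1`) gives 31100 nM, the only true number available, so its standing can be given only as weak cytotoxicity on an absolute reading, with no measured neighbour for comparison.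

The next compound is compound 3 (`COc1ccc2c(C(=O)/C(C#N)=C/c3c[nH]c4ccccc34)c[nH]c2c1`). It carries hydrogen in place of methoxy on an aromatic carbon, the change being (hydrogen in place of methoxy on an aromatic carbon). Among the measured compounds shown here, no measured pair isolates this kind of change, so the expectation rests on compound 2 at 31100 nM alone. No shift beyond the usual scatter of this assay is expected, and no direction can be favoured. The expected change is a 1.0-fold lower number from compound 2 to compound 3 (0.02 log units; within the scatter). For compound 3 the estimated value is 30000 nM, with an expected range of 10000 nM to 50000 nM. A report of a limit only would not be surprising.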

Compound 3, half-maximal inhibitory concentration: > 50000 nM
Compound 3 ended at the assay's limit; the forecaster's own chance of this, stated with the estimate: 35%; at least 1.6-fold (0.22 log units) between middle value and limit.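

In this assay, among these compounds, hydrogen in place of methoxy on an aromatic carbon gives an at least 1.6-fold higher number from compound 2 to compound 3 (0.20 log units; that floor lies within the scatter), the first step to isolate this change, and at this position, meta to a fused ring and para to a fused ring, it brings no lower number. The reading for compound 3 is a limit of the assay and not a number, so only a floor for the step is available, and that floor lies within the usual scatter, leaving the size of the loss unsettled. As far as these compounds go, the step from compound 1 to compound 3 cannot be read, and the upper size of the step to compound 3 stays unknown, since the series is crowded at the ceiling of the assay: the limit of > 50000 nM in this assay, at which 2 of the 3 values shown sit.

From the compounds shown here alone, whether a hydroxy group, a fluorine atom or an amine on this same aromatic carbon would bring the number below that of compound 2 remains open. Also open, going by these compounds, is whether a longer chain in place of the remaining methoxy, or a carboxylic acid in place of the nitrile, would move the shared core away from the limit at all.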